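The compounds below may be only part of what the source reports. "The series", "measured", "known", "first", "only" and "open" are said of these compounds alone.

Compound 1 `Cc1ccc(S(=O)(=O)NCc2cn(C[C@H](O)[C@H]3OC(=O)C(OCc4ccccc4)=C3OCc3ccccc3)nn2)cc1`: 14400 nM in a functional assay on HeLa cells (Homo sapiens) for antiproliferative activity, read by MTT assay, with a stated time of 72 h; on this read-out higher numbers stand for weaker inhibition and lower numbers for stronger inhibition
Compound 2 `O=C1O/C(=C\Cn2cc(-c3cc(F)cc(F)c3)nn2)C(OCc2ccccc2)=C1OCc1ccccc1`: 17700 nM
Compound 3 `O=C1O[C@H]([C@@H](O)Cn2cc(CNS(=O)(=O)c3ccc(Cl)cc3F)nn2)C(OCc2ccccc2)=C1OCc1ccccc1`: 20700 nM

On these numbers compound 2 stands second highest of three: compound 3 sits nearest, higher by an amount within the scatter, and compound 1 furthest, lower by an amount also within the scatter, so the three cannot be told apart. Compound 4 `COc1ccccc1-c1cn(C/C=C2\OC(=O)C(OCc3ccccc3)=C2OCc2ccccc2)nn1` differs from compound 2 in one place: 2-methoxyphenyl in place of 3,5-difluorophenyl on an aromatic carbon. For the measured compounds named here, the only measured step, a 1.4-fold higher number from compound 1 to compound 3 (0.16 log units; within the scatter), swaps one aromatic group for another on a sulfonyl sulfur, a different part of the molecule, and lay within the scatter; it bears on the new change only loosely. Going by the values given here, no step tests the group on the five-membered aromatic ring with 3 nitrogen, so no shift beyond the scatter is expected in this assay. The step expected is a 1.0-fold higher number from compound 2 to compound 4 (0.01 log units; within the scatter). Compound 4 is therefore estimated at 18000 nM, with a range from 7000 nM to 45000 nM.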

Compound 4, half-maximal inhibitory concentration: > 100000 nM
Compound 4: no number, only a limit; the forecaster's own chance of this, stated with the estimate: 15%; at least 5.5-fold (0.74 log units) between middle value and limit.
By their numbers in this assay, from the lowest: compounds 1, 2 and 3 (each within the scatter of the next). At a limit, above all of these: compound 4.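

For the compounds shown here, the group on the five-membered aromatic ring with 3 nitrogen matters in this assay: 2-methoxyphenyl in place of 3,5-difluorophenyl brings an at least 5.6-fold higher number from compound 2 to compound 4 (0.75 log units; beyond the scatter), the only step here beyond the scatter. Compound 4 gives no number, only a limit of the assay: the limit of > 100000 nM in this assay, at which 1 of the 4 values shown sits. On these data alone, the full size of this step therefore stays unknown.

This single pair cannot separate the effect of the methoxy group from that of losing the two fluorines. As far as these compounds go, how a plain phenyl or an aminophenyl would behave at this position also stays open.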